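Benzothiazolylsulfanyl to benzimidazolyloxy on the ketone-side chain

The compounds below may be only part of what the source reports. "The series", "measured", "known", "first", "only" and "open" are said of these compounds alone.

Compound 2 `CC(C)[C@H](NC(=O)COc1cccc2ccccc12)C(=O)N[C@@H](CC(=O)O)C(=O)CSc1nc2ccccc2s1` carries a (1,3-benzothiazol-2-yl)sulfanyl group on a saturated chain carbon bound to a carbonyl carbon. In a functional assay on Jurkat cells (Homo sapiens) for inhibition (a higher number here means a weaker inhibitor, a lower number a stronger inhibitor), compound 2 gives only a limit, > 200000 nM, and no number. The related compound 1 `CC(C)[C@H](NC(=O)COc1cccc2ccccc12)C(=O)N[C@@H](CC(=O)O)C(=O)COc1cc(C(F)(F)F)n(C)n1` gives 46000 nM in this assay. For the measured compounds named here, the single measured step, an at least 4.3-fold higher number from compound 1 to compound 2 (0.63 log units; beyond the scatter), is thus itself only a bound, resting on (the limit of > 200000 nM in this assay, at which 1 of the 2 values shown sits).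

Compound 3 `CC(C)[C@H](NC(=O)COc1cccc2ccccc12)C(=O)N[C@@H](CC(=O)O)C(=O)COc1nc2ccccc2[nH]1` differs from compound 2 by (1H-benzimidazol-2-yl)oxy in place of (1,3-benzothiazol-2-yl)sulfanyl on a saturated chain carbon bound to a carbonyl carbon. Going by the values given here, no measured step covers this exchange directly; the one step known changes both the chain linkage and the ring, and runs toward the limit rather than away from it. With compound 2 standing at a limit, any step an at least 1.6-fold lower number from compound 2 to compound 3 (0.22 log units; that floor lies within the scatter) is expected to point toward a lower number, if it is resolved at all, and the size is uncertain. Compound 3 is therefore expected to give about 120000 nM in this assay, within a range from 25000 nM to 400000 nM, and with a fair chance that again only a limit is reported.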

Compound 3, half-maximal inhibitory concentration: > 200000 nM
Compound 3 ended at the assay's limit; the forecaster's own chance of this, stated with the estimate: 50%; at least 1.6-fold (0.22 log units) between middle value and limit.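

In this assay compound 3 also gives only a limit, > 200000 nM, and the step between compound 2 and compound 3 cannot be read. The new information comes from keeping the oxygen linkage fixed: 1H-benzimidazol-2-yl in place of 1-methyl-5-(trifluoromethyl)-1H-pyrazol-3-yl gives an at least 4.3-fold higher number from compound 1 to compound 3 (0.63 log units; beyond the scatter), so at this position a change of the group on the oxygen alone moves the number beyond the scatter, whereas the earlier step changed the linking atom and the ring together. Compound 1 remains the only one of the three with a readable value, which leaves this position poorly resolved in this assay: the limit of > 200000 nM in this assay, at which 2 of the 3 values shown sit.

On these data alone, the effect of the linking atom by itself stays open, as oxygen and sulfur are compared here only alongside a change of ring. Also open, as far as these compounds go, is which part of the 1-methyl-5-(trifluoromethyl)-1H-pyrazol-3-yl group carries the difference from compound 3, for instance whether a plain methyl in place of the trifluoromethyl, or a simple phenyl on the oxygen, would keep the number of compound 1 or push it to the limit.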